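Trimethoxyphenyl Replaces Ethyl on an Inactive Core

This account rests on a few compounds, and the source may have more. Where it says the series, first, only, none or still open, it means among the compounds named here.

Of the compounds shown here, three sharing one core have been tested in a functional assay on MKN-45 cells (Homo sapiens) for cytotoxicity, read by MTT assay, with a stated time of 48 h; on this read-out lower numbers stand for stronger inhibition and higher numbers for weaker inhibition. Compound 1 `CCc1nnc(SCC(=O)c2ccccc2)n1N1C(=O)c2ccccc2C1=O` gives > 200000 nM there, which is a limit of the assay rather than a measured number. Compound 2 `CCc1nnc(SCC(=O)c2ccc(C)cc2)n1N1C(=O)c2ccccc2C1=O` likewise gives > 200000 nM, again a limit. Compound 3 `CCc1nnc(SC)n1N1C(=O)c2ccccc2C1=O` gives > 200000 nM, also a limit. Because all three sit at the limit of > 200000 nM in this assay, at which 3 of the 3 values shown sit, the steps among them cannot be sized: a step that the two limits leave unreadable from compound 1 to compound 2, a step that the two limits leave unreadable from compound 1 to compound 3 and a step that the two limits leave unreadable from compound 2 to compound 3 all remain unreadable. Compound 2 therefore stands at the limit of this assay, with no potency number of its own. The unmeasured compound 4 `COc1cc(-c2nnc(SCC(=O)c3ccc(C)cc3)n2N2C(=O)c3ccccc3C2=O)cc(OC)c1OC` differs from compound 2 by 3,4,5-trimethoxyphenyl in place of ethyl on an aromatic carbon. Among the compounds with values here, none of the measured steps changes this position or this group, so they give no readable guide to how large the step should be or which way it should go. Compound 4 is expected to give about 120000 nM in this assay, within a range from 20000 nM to 400000 nM. This estimate amounts to an expected step of an at least 1.6-fold lower number from compound 2 to compound 4 (0.22 log units; that floor lies within the scatter), whose direction the limits leave open.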

Compound 4, half-maximal inhibitory concentration: 9620 nM
The estimate for compound 4 lay 12-fold (1.10 log units) above the measured number; measured number below the stated range.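

Placing 3,4,5-trimethoxyphenyl in place of ethyl on the aromatic carbon of the five-membered ring gives, in this assay, an at least 20-fold lower number from compound 2 to compound 4 (1.31 log units; beyond the scatter). Within the data shown here, this is the first readable change, showing that this position can shift the read-out, whereas the earlier steps, all at the group on sulfur, cannot be read. Compound 4 is also the only compound shown with a measured number instead of a limit: the limit of > 200000 nM in this assay, at which 3 of the 4 values shown sit.

The compounds shown leave open whether the gain needs the whole 3,4,5-trimethoxyphenyl group, since a plain phenyl ring, a single methoxy on that ring or a longer chain such as butyl is not among them. From the compounds shown here alone, it also remains open whether the same swap would give a readable number with the benzoyl group of compound 1 or the hydrogen of compound 3.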